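The source may hold more compounds than are shown below. What is called first, only, known or untested is meant among the compounds shown, and "the series" means these compounds.

Among the measured compounds shown here, compound 2, whose structure is `CC(O)C#Cc1cc(Cl)cn2c([N+](=O)[O-])c(CS(=O)(=O)c3ccccc3)nc12`, is the only compound here with a plain number in an ADME assay on HepG2 cells (Homo sapiens) for cytotoxicity, read by MTT assay, with a stated time of 72 h (a lower number here means that less compound is tolerated, a higher number that more compound is tolerated), and in this assay compound 2 gives 44200 nM. Compound 1, with the structure `Nc1ccc(C#Cc2cc(Cl)cn3c([N+](=O)[O-])c(CS(=O)(=O)c4ccccc4)nc23)cc1`, has no number in this assay but only a limit, which for compound 1 stands at > 3900 nM. For the measured compounds named here, the one step between measured compounds, a step that the limit leaves unreadable from compound 1 to compound 2, cannot be read in size because of the limit of > 3900 nM in this assay, at which 1 of the 2 values shown sits, so it gives no guide to how much a change at the triple-bonded carbon shifts the read-out.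

Compound 3, with the structure `O=[N+]([O-])c1c(CS(=O)(=O)c2ccccc2)nc2c(C#CC3(O)CCCC3)cc(Cl)cn12`, is not yet measured. It differs from compound 2 in one place: 1-hydroxycyclopentyl in place of 1-hydroxyethyl on a triple-bonded carbon. The group that enters keeps the same donor and acceptor count as the one that leaves, with the ring as the added feature. Going by the values given here, no measured step shows what such a ring does here. The expectation for compound 3 is therefore a step of a 1.1-fold lower number from compound 2 to compound 3 (0.04 log units; within the scatter), staying within the usual scatter, and compound 3 is estimated to give 40000 nM, in the range 18000 nM to 90000 nM.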

Compound 3, half-maximal cytotoxic concentration: > 31300 nM
Compound 3 was reported as a limit; the forecaster's own chance of this, stated with the estimate: 10%; the middle value does not contradict the limit.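

Neither new step can be read in size, from compound 2 to compound 3 or from compound 1 to compound 3, because compound 3 gives only a limit in this assay and compound 1 does too: the limit of > 31300 nM in this assay, at which 1 of the 3 values shown sits. From the compounds shown here alone, what remains open is how far 1-hydroxycyclopentyl on a triple-bonded carbon, in place of 1-hydroxyethyl or 4-aminophenyl, shifts the read-out in this assay for these compounds.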